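Bromophenyl to difluorophenyl: expected tolerance of compound 4

The source may report more compounds than this note shows. Statements on the series, on what has been measured and on what is new or still open speak of the compounds shown alone.

Compound 1 `COc1cc(-c2nnc(SCc3cccc(Br)c3)o2)ccc1O` gives 382000 nM in an ADME assay on cells (Mus musculus, strain BALB/c) for cytotoxicity, read by MTT assay, with a stated time of 24 h (a lower number here means that less compound is tolerated, a higher number that more compound is tolerated), and it stands alongside compound 2 `COc1cc(-c2nnc(SCc3ccccc3[N+](=O)[O-])o2)ccc1O` at 331000 nM and compound 3 `COc1cc(-c2nnc(SCc3cccc([N+](=O)[O-])c3)o2)ccc1O` at 392000 nM, all three within the scatter of one another. Going by the values given here, the one step through a single change, a 1.0-fold higher number from compound 1 to compound 3 (0.01 log units; within the scatter), puts nitro in place of bromo on an aromatic carbon and leaves the number where it was. Compound 4 `COc1cc(-c2nnc(SCc3ccc(F)cc3F)o2)ccc1O` differs from compound 1 by 2,4-difluorophenyl in place of 3-bromophenyl on a saturated chain carbon bound to a sulfur. Among the compounds with values here, no measured step covers this exchange directly; the step from compound 1 to compound 3 is the nearest analogy, and it stayed within the scatter. The step of a 1.0-fold lower number from compound 1 to compound 4 (0.00 log units; within the scatter) is therefore expected to stay within the scatter. The estimate for compound 4 is 380000 nM, ranging from 200000 nM to 700000 nM.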

Compound 4, half-maximal cytotoxic concentration: 520000 nM
For compound 4 the middle estimate is 1.4-fold (0.14 log units) below the measured one; low and high end bracket the measured number.
By their numbers in this assay, from the lowest: compounds 2, 1, 3 and 4 (each within the scatter of the next).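

In this assay the step of a 1.4-fold higher number from compound 1 to compound 4 (0.13 log units; within the scatter) stays within the scatter, so this place on a saturated chain carbon bound to a sulfur accepts 2,4-difluorophenyl for 3-bromophenyl, with two fluorines for one bromine, without a difference the assay can resolve. This is a second exchange from compound 1 that stays within the scatter, and here the ring's halogen substitution itself is what changes. No available evidence bears on this result. Going by these compounds, all four compounds carry a substituted phenyl at this place, so it remains open whether an amine, a carboxylic acid or a longer chain there would also stay within the scatter.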